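Hydrogen in place of methoxy on compound 2

A few compounds are considered here, and "the series" means these few. Any claim that something is new, unique, unknown or untested is made for them only; others in the source may bear on it.

Of the compounds shown here, two have numbers so far. In a functional assay on HepG2 cells (Homo sapiens) for inhibition, read by MTT assay, with a stated time of 72 h (a lower number here means a stronger inhibitor, a higher number a weaker inhibitor), compound 1 `COc1ccc(/C=C\c2cccc3c2oc(=O)n3C)cc1` gives 47200 nM and compound 2 `COc1cc(/C=C\c2cccc3c2oc(=O)n3C)cc(OC)c1OC` gives 1070 nM. Compound 2 holds the lower of the two numbers, and its gap to compound 1 lies beyond the scatter.

Next in line is compound 3 `COc1cc(/C=C\c2cccc3c2oc(=O)n3C)cc(OC)c1`, which differs from compound 2 in one place: hydrogen in place of methoxy on an aromatic carbon. Hydrogen stands in place of methoxy on an aromatic carbon, ortho to two methoxy groups and para to a large group. Among the compounds with values here, no measured pair isolates this change, so the expectation rests on thin evidence. Compared with compound 2, compound 1 carries fewer methoxy groups and sits at 47200 nM. On that basis, the number in this assay is expected to rise, probably without reaching that value. The expected change is a 6.5-fold higher number from compound 2 to compound 3 (0.82 log units; beyond the scatter), upward and beyond the scatter. For compound 3 the estimate is 7000 nM, with an expected range of 1800 nM to 30000 nM.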

Compound 3, half-maximal inhibitory concentration: 4250 nM
For compound 3 the middle estimate is 1.6-fold (0.22 log units) above the measured one; low and high end bracket the measured number.
By their numbers in this assay, from the lowest: compound 2; then compound 3; then compound 1.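

In this assay, within the data shown here, the swap of methoxy for hydrogen on the aromatic carbon ortho to two methoxy groups and para to a large group gives a 4.0-fold higher number from compound 2 to compound 3 (0.60 log units; beyond the scatter), the first measured step to isolate a single position. The step lies beyond the scatter, so the methoxy on this carbon has a measurable bearing on the number, although compound 3 remains a measurable inhibitor at 4250 nM without it. No available evidence accounts for the size or direction of this step.

The compounds shown leave open whether this step depends on methoxy itself or would also appear with another group on the same carbon, such as a hydroxyl, an ethoxy group, a fluorine atom or an amine. They also leave open how much each of the two methoxy groups retained in compound 3 contributes on its own, and whether the step would keep its size with a different substitution pattern on this ring.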